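The source may report more compounds than this note shows. Statements on the series, on what has been measured and on what is new or still open speak of the compounds shown alone.

Working notes on the series. Compound 1 `CCOC(=O)C1=C(Nc2ccccc2)S/C(=C\c2ccc(OC)cc2)C1=O` was tested in a functional assay on MCF7 cells (Homo sapiens) for inhibition, read by MTT assay, with a stated time of 72 h, tested at 10 uM (a lower number here means less inhibition, a higher number more inhibition at the concentration tested (going by the name of the read-out)), and gives 14.7%. Compound 3 `CCOC(=O)C1=C(Nc2ccccc2)S/C(=C\c2cc(OC)c(O)c(OC)c2)C1=O` gives 12.9% in this assay, a value within the scatter of that for compound 1, so the two cannot be told apart. For compound 2 `CCOC(=O)C1=C(Nc2ccccc2)S/C(=C\c2ccccc2C(F)(F)F)C1=O` the read-out in this assay is only a limit, < 10%. No number shown exceeds that of compound 1, and all values sit low.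

Compound 4 `CCOC(=O)C1=C(Nc2ccccc2)S/C(=C\c2ccc[nH]2)C1=O` is not yet measured. Relative to compound 1 the change is 1H-pyrrol-2-yl in place of 4-methoxyphenyl on a double-bonded chain carbon bound to a double-bonded ring carbon. Going by the values given here, no measured pair covers a change of this kind. The step from compound 1 to compound 4 is expected to stay within the scatter: a number 1.7 percentage points lower from compound 1 to compound 4 (within the scatter). Compound 4 is estimated at 13% in this assay, with a range from 5% to 24%.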

Compound 4, a percentage reported as inhibition, at one concentration (the size of the read-out at that concentration, not a potency): 18.3%
For compound 4 the middle estimate is 5.3 percentage points below the measured one, within the range that was stated.
By their numbers in this assay, from the lowest: compounds 3, 1 and 4 (each within the scatter of the next). At a limit, below all of these: compound 2.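

At this position, on a double-bonded chain carbon bound to a double-bonded ring carbon, the series now includes a five-membered aromatic ring with a hetero atom, and the exchange for 4-methoxyphenyl gives no readable change in this assay: a number 3.6 percentage points higher from compound 1 to compound 4 (within the scatter). A six-membered aromatic ring of carbon only is therefore not needed here to keep this low level of inhibition. One compound remains outside any numerical comparison: the limit of < 10% in this assay, at which 1 of the 4 values shown sits.

Open, on these data alone, is how a carboxylic acid or an amine at this place would read. Changes elsewhere on the shared core also remain open, for example an amine in place of the ethyl ester.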